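Ether chain terminus on the chloro core: compound 4

The compounds below may be only part of what the source reports. "The series", "measured", "known", "first", "only" and "open" are said of these compounds alone.

Measured so far:
compound 1 `CCCCOc1ccc2c(Cl)ccnc2c1` gives 3610 nM in a functional assay on BGC-823 cells (Homo sapiens) for cytotoxicity, read by MTT assay, with a stated time of 48 h; on this read-out higher numbers stand for weaker inhibition and lower numbers for stronger inhibition
compound 2 `CN(C)CCNc1ccnc2cc(OCc3ccccc3)ccc12` gives 1250 nM in this assay
compound 3 `C=CCOc1ccc2c(NCCN(C)C)ccnc2c1` gives 1360 nM in this assay

Compound 1 carries the highest number of the three in this assay; compound 3 sits a clear margin lower, compound 2 slightly lower still, and both of those gaps lie beyond the scatter. Compound 4 `Clc1ccnc2cc(OCCc3ccccc3)ccc12` keeps the chloro core of compound 1 and changes the ether chain: phenyl in place of ethyl on a saturated chain carbon, two bonds along the chain from an oxygen on an aromatic ring.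

Among the compounds with values here, only one measured step speaks to a swap of this sort. Between compound 2 and compound 3 the group on the saturated chain carbon bound to the ether oxygen goes from phenyl to vinyl, and a 1.1-fold higher number from compound 2 to compound 3 (0.04 log units; within the scatter). Within the data shown here, that step sits on a different core and at a different point on the chain, but it is the nearest precedent, and it shows an aryl-for-alkyl exchange on the ether leaving the number essentially where it was. No comparison on the chloro core itself is available.

On that basis the step from compound 1 to compound 4 is expected to be small, a 1.2-fold lower number from compound 1 to compound 4 (0.08 log units; within the scatter), with no direction that the data support beyond the scatter. Compound 4 is therefore estimated at 3000 nM in this assay, within a range of 1200 nM to 9000 nM.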

Compound 4, half-maximal inhibitory concentration: 2010 nM
Compound 4: the middle estimate sits 1.5-fold (0.17 log units) above what was measured; measured number inside the range.
By their numbers in this assay, from the lowest: compounds 2, 3, 4 and 1 (each within the scatter of the next, the first and the last beyond it).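

On the core of compound 1, phenyl in place of ethyl on a saturated chain carbon, two bonds along the chain from an oxygen on an aromatic ring, gives in this assay a 1.8-fold lower number from compound 1 to compound 4 (0.25 log units; within the scatter). Within the data shown here, this is the first reading of such a change on this core and at this place, and it shows that the one six-membered aromatic ring can enter there without moving the number beyond the scatter. The only other measured exchange on an ether chain, on a different core and at a different place on the chain, gives a 1.1-fold higher number from compound 2 to compound 3 (0.04 log units; within the scatter), so neither of the two single-place changes on the ether chain shown here leaves the scatter, and no measurement on hand bears on what lies behind either step.

One step on this core does not say whether the change would read the same on the core of compound 2 or compound 3, where a different group replaces the chloro group. Nor does it say how the number would respond to a carboxylic acid, a morpholine or a longer chain in place of the phenyl.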